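This account rests on a few compounds, and the source may have more. Where it says the series, first, only, none or still open, it means among the compounds named here.

Of the compounds shown here, two from one series have been tested so far, and a third is still to come. Compound 1, `Cc1nc2c(OCc3ccccc3)cccn2c1C(N)=O`, and compound 2, `Cc1nc2c(OCc3ccccc3)cccn2c1COC(=O)c1cccnc1`, share one core and were both examined in a functional assay on the whole organism (stomach) for inhibition, with Canis familiaris (Canis lupus familiaris) as the target, at a dose of 5 mg/kg by the intravenous route; on this read-out higher numbers stand for a stronger effect at the one dose given and lower numbers for a weaker effect. In this assay compound 1 gives 2%, while compound 2 gives 88%. Of the two numbers, compound 2 holds the higher one, and its distance from compound 1 is well beyond the scatter seen in repeat measurements, so the two compounds clearly differ in this read-out.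

The next compound, compound 3, `Cc1nc2c(OCc3ccccc3)cccn2c1COC(=O)N(C)C`, is built from compound 2 by one exchange: dimethylamino in place of pyridin-3-yl on a carbonyl carbon. Among the measured compounds shown here, no measured pair shows this exact exchange, so there is no precedent within the data for the size of its effect. The expectation is that compound 3 keeps much of the activity of compound 2, with a moderate downward step in this assay, described by a number 28 percentage points lower from compound 2 to compound 3 (beyond the scatter). On that basis compound 3 is estimated to give 60% in this assay, with a plausible range from 25% to 90%.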

Compound 3, a percentage reported as inhibition, in the whole organism at one dose (the size of the read-out at that dose, not a potency): 23%
Beside the measured number, compound 3's estimate is 37 percentage points above it; the whole stated range lies above it.
By their numbers in this assay, from the lowest: compound 1; then compound 3; then compound 2.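

In this assay the group on the carbonyl carbon turns out to matter a great deal: dimethylamino in place of pyridin-3-yl goes with a number 65 percentage points lower from compound 2 to compound 3 (beyond the scatter), so this position does not accept any group equally well. The same compound 3 also shows that the side chain alone accounts for only a small part of the effect, as ((dimethylcarbamoyl)oxy)methyl in place of carbamoyl on an aromatic carbon goes with a number 21 percentage points higher from compound 1 to compound 3 (beyond the scatter), which leaves compound 3 far short of compound 2. Nothing available explains why pyridin-3-yl does so much better than dimethylamino at this place.

The compounds shown leave open whether the whole aromatic ring counts or its ring nitrogen in particular, a question that a phenyl group or a pyridin-4-yl group on the same carbonyl carbon could help to separate. They also do not tell whether a simple methyl group or a larger diethylamino group at this place would land nearer to compound 3 or nearer to compound 2.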